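The source may report more compounds than this note shows. Statements on the series, on what has been measured and on what is new or still open speak of the compounds shown alone.

Measured so far:
- compound 1, `CN(C)/C(=N/CCCCn1nc(-c2ccccc2)ccc1=O)NC#N`: 30.3 mg/kg
- compound 2, `C/N=C(/NC#N)NCCCCCCn1nc(-c2ccccc2)ccc1=O`: > 100 mg/kg

Going by the values given here, in a functional assay on the whole organism (stomach) with Rattus norvegicus as the target (a higher number here means that more compound is needed for the effect, a lower number that less compound is needed), compound 1 gives 30.3 mg/kg and is the only compound of the pair with a number. Among the compounds with values here, compound 2 reaches only the limit of > 100 mg/kg in this assay, at which 1 of the 2 values shown sits, in this assay; this is a limit of the assay, not a number, so no step between compound 1 and compound 2 can be sized. Compound 3, `CC/N=C(/NC#N)NCCCCn1nc(-c2ccccc2)ccc1=O`, differs from compound 1 by a group of 8 heavy atoms (4 carbon, 4 nitrogen; no ring) in place of a group of 8 heavy atoms (4 carbon, 4 nitrogen; no ring), on a saturated chain carbon, four bonds along the chain from an aromatic nitrogen. Within the data shown here, no measured step of this kind exists, so the direction can only be guessed from the two compounds known. Among the measured compounds shown here, the change keeps the chain length of compound 1, which is the only compound with a number, so the step from compound 1 to compound 3 is expected to stay within the usual scatter or to lower the dose slightly, as a 1.5-fold lower number from compound 1 to compound 3 (0.18 log units; within the scatter). Compound 3 is therefore estimated at 20 mg/kg in this assay, with a range from 6 mg/kg to 70 mg/kg.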

Compound 3, dose for half-maximal effect: 92 mg/kg
For compound 3 the middle estimate is 4.6-fold (0.66 log units) below the measured one; measured number outside the range, above it.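

In this assay, the same atoms joined differently give a 3.0-fold higher number from compound 1 to compound 3 (0.48 log units; beyond the scatter), so the dose at this position, on a saturated chain carbon, four bonds along the chain from an aromatic nitrogen, depends on how the atoms of the group are arranged and not only on which atoms are present. The step is modest but beyond the scatter, and it runs towards more compound being needed, which makes compound 1 the better of the two at this chain length. The entering group counts 2 hydrogen-bond donors against 1 in the leaving group, but nothing on hand ties the step to that count or gives any other cause for it.

Compound 2 gives only a limit of the assay, > 100 mg/kg, and steps to it cannot be read. Open, from the compounds shown here alone, is how a urea or an amine in place of this group, or a longer chain carrying the group of compound 1, would change the dose.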